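The compounds below may be only part of what the source reports. "The series", "measured", "known", "first", "only" and "open" are said of these compounds alone.

Measured compounds in a functional assay on cells (Melanoma cell, Homo sapiens) for cytotoxicity, read by sulforhodamine B assay, with a stated time of 48 h; a higher number here means a weaker inhibitor of growth, a lower number a stronger inhibitor of growth:
- compound 1 `CN(C)c1ccc(C2CC(c3ccccc3)=NN2C2=NC(=O)/C(=C3\C(=O)Nc4ccc(Br)cc43)S2)cc1` — 460 nM
- compound 2 `CN(C)c1ccc(C2CC(c3ccccc3)=NN2C2=NC(=O)/C(=C3\C(=O)Nc4ccc(Cl)cc43)S2)cc1` — 570 nM
- compound 3 `COc1ccc(-c2cc(-c3ccc(Cl)cc3)n(C3C(=O)Nc4ccc(Br)cc43)n2)cc1` — 49300 nM

Compound 1 and compound 2 share a core and differ by one change, (chloro in place of bromo on an aromatic carbon). The step is a 1.2-fold higher number from compound 1 to compound 2 (0.09 log units; within the scatter). Compound 3 stands on a different core; the difference between the two cores is not broken down here. In this assay compound 3 gives a number far from those of compound 1 and compound 2, and both gaps lie beyond the scatter.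

Compound 4 `COc1ccc(-c2cc(-c3ccc(Cl)cc3)n(C3C(=O)Nc4ccc(Cl)cc43)n2)cc1` carries the same change on the core of compound 3: chloro in place of bromo on an aromatic carbon. The place is the same in both pairs, so the change is the same. Since the measured instance of this change between compound 1 and compound 2 stays within the scatter, the expected step is a 1.1-fold higher number from compound 3 to compound 4 (0.05 log units; within the scatter), resting on the value of compound 3 and on the measured step from compound 1 to compound 2. Compound 4 is therefore expected at about 55000 nM in this assay. For compound 4 the expected range runs from 25000 nM to 120000 nM.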

Compound 4, concentration for total growth inhibition: 46700 nM
Beside the measured number, compound 4's estimate is 1.2-fold (0.07 log units) above it; measured number inside the range.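

In this assay, chloro in place of bromo on an aromatic carbon gives a 1.1-fold lower number from compound 3 to compound 4 (0.02 log units; within the scatter), so on this second core the change again leaves the number unmoved beyond the scatter. Across the series, the two measured instances of this change agree: the same change on two cores in this assay, a 1.2-fold higher number (0.09 log units; within the scatter) from compound 1 to compound 2 and a 1.1-fold lower number (0.02 log units; within the scatter) from compound 3 to compound 4, 1.3-fold (0.12 log units) apart, within the scatter of two such steps. This shows that the exchange of these halogens is equally silent on both cores in this assay, but it does not show that a change with a measurable step would carry across, nor that the agreement would hold on a further core or in a different assay.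

Left open is whether a different group on the same aromatic carbon, such as fluoro, a nitrile or an amine, would give a step beyond the scatter on either core, and whether that step would be the same on both. Also open, going by these compounds, is whether a change elsewhere on these cores, such as a longer chain in place of the methoxy group of compound 3, would carry from one core to the other.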